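Hydroxy in Place of the Aryl Ketone on a Shared Core

The compounds below may be only part of what the source reports. "The series", "measured", "known", "first", "only" and "open" are said of these compounds alone.

Compound 1 `COc1ccc2c(c1)C(n1ccccc1=O)=CC(C)(C)O2`: 5.99
Compound 2 `Cc1ccccc1C(=O)c1ccc2c(c1)C(n1ccccc1=O)=CC(C)(C)O2`: 6.25

In a functional assay (trachea) with Rattus norvegicus as the target (on this read-out higher numbers stand for higher potency (the scale is a negative logarithm) and lower numbers for lower potency), compound 2 gives the higher of the two numbers, though the step of a number 0.26 log units higher from compound 1 to compound 2 (within the scatter) lies within the scatter. Compound 3 `CC1(C)C=C(n2ccccc2=O)c2cc(O)ccc2O1` differs from compound 2 by hydroxy in place of (2-methylphenyl)carbonyl on an aromatic carbon. Within the data shown here, no measured step exchanges an aryl ketone for a hydroxy group; the only step at that position, a number 0.26 log units higher from compound 1 to compound 2 (within the scatter), stayed within the scatter, so a replacement of the same group by a single oxygen is expected to move little. The estimate for compound 3 is 5.95, between 5.35 and 6.55, a step of a number 0.30 log units lower from compound 2 to compound 3 (within the scatter) that is expected to fall within the scatter.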

Compound 3, logarithm of the reciprocal of the active concentration, log(1/C): 5.31
Compound 3: the middle estimate sits 0.64 log units above what was measured; the measured number lies below the stated range.
By their numbers in this assay, from the lowest: compound 3; then compounds 1 and 2 (each within the scatter of the next).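

In this assay this position is not indifferent to what it carries: methoxy and (2-methylphenyl)carbonyl had stayed within the scatter of each other, but hydroxy gives a number 0.94 log units lower from compound 2 to compound 3 (beyond the scatter) and a number 0.68 log units lower from compound 1 to compound 3 (beyond the scatter). The second step is only hydrogen in place of methyl on the oxygen, so that single methyl is enough to separate the two numbers. Nothing at hand accounts for this drop. As far as these compounds go, it remains open whether an amine or a carboxylic acid on that aromatic carbon would behave like hydroxy, and whether a longer chain on the oxygen would behave like methyl.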